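This account rests on a few compounds, and the source may have more. Where it says the series, first, only, none or still open, it means among the compounds named here.

Compound 2 `NNC(=O)c1cc2ccc(OCc3ccccc3)cc2oc1=O` carries a hydrazide on the shared core together with a plain benzyl ether. In a functional assay on HeLa cells (Homo sapiens) for cytotoxicity, read by MTT assay, with a stated time of 72 h (on this read-out lower numbers stand for stronger inhibition and higher numbers for weaker inhibition), compound 2 reaches only a limit of the assay, > 100000 nM. Compound 3 `NNC(=O)c1cc2ccc(OCc3cccc(Br)c3)cc2oc1=O` differs from it by bromo in place of hydrogen on an aromatic carbon. In this assay compound 3 likewise stops at a limit, > 100000 nM. The step from compound 2 to compound 3 is a step that the two limits leave unreadable from compound 2 to compound 3 because the limit of > 100000 nM in this assay, at which 2 of the 3 values shown sit, swallows both values. Compound 1 `O=C(NCCO)c1cc2ccc(OCc3ccc([N+](=O)[O-])cc3)cc2oc1=O`, which bears a hydroxyethyl amide instead of the hydrazide and carries a nitro group on the benzyl ring, gives 6890 nM in this assay. Compound 4 `NNC(=O)c1cc2ccc(OCc3ccc([N+](=O)[O-])cc3)cc2oc1=O` is obtained from compound 2 by nitro in place of hydrogen on an aromatic carbon. Within the data shown here, the only measured step that touches the hydrazide series, from compound 2 to compound 3, cannot be read in size, and no measured pair joins compound 1 to compound 4. Compound 4 is therefore expected to stay near the limit, with an expected step of an at least 1.2-fold lower number from compound 2 to compound 4 (0.09 log units; that floor lies within the scatter). The estimate for compound 4 is 80000 nM, from 20000 nM to 250000 nM.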

Compound 4, half-maximal inhibitory concentration: > 100000 nM
Compound 4 ended at the assay's limit (the forecaster's own chance of this, stated with the estimate: 60%); middle value at least 1.2-fold (0.09 log units) away from the limit.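

With the nitro group held in place on the benzyl ring, amino in place of 2-hydroxyethyl on the amide-type nitrogen gives an at least 14-fold higher number from compound 1 to compound 4 (1.16 log units; beyond the scatter) in this assay. Among these compounds, this is the first step here that can be sized, and it is large, so the group on that nitrogen separates compound 1 from compound 4. On the hydrazide, nitro gives no more of a readable value than bromo did, and the steps among compound 2, compound 3 and compound 4 cannot be read: the limit of > 100000 nM in this assay, at which 3 of the 4 values shown sit.

As far as these compounds go, the true size of the step to compound 4 stays open, since only its floor is known. Also open, from the compounds shown here alone, is whether the hydroxyethyl amide keeps its value with a plain benzyl ether, and whether a methyl amide, a 3-hydroxypropyl amide or a carboxylic acid would do the same on the shared core.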